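The source may hold more compounds than are shown below. What is called first, only, known or untested is meant among the compounds shown, and "the series" means these compounds.

In a functional assay on DU-145 cells (Homo sapiens) for cytotoxicity, read by trypan blue exclusion, with a stated time of 96 h (a higher number here means a weaker inhibitor, a lower number a stronger inhibitor), compound 1 `COc1ccc(NS(=O)(=O)/C=C/c2c(OC)cccc2OC)cc1` gives 375 nM and compound 2 `COc1ccc(NS(=O)(=O)/C=C/c2c(OC)cc(OC)cc2OC)cc1` gives 200 nM, two values within the scatter of each other. Compound 3 `COc1cc(OC)c(/C=C/S(=O)(=O)Nc2ccc(OC)c(OP(=O)(O)O)c2)c(OC)c1` differs from compound 2 by a group of 5 heavy atoms (4 oxygen, 1 phosphorus; no ring) in place of a hydrogen atom, on an aromatic carbon, on an aromatic carbon, ortho to a methoxy group. For the measured compounds named here, the only measured step, a 1.9-fold lower number from compound 1 to compound 2 (0.27 log units; within the scatter), brought in a methoxy group in place of hydrogen, so it sets no size or direction for this different change. No shift beyond the scatter is expected in this assay, though with wide uncertainty. The expected step is a 1.3-fold lower number from compound 2 to compound 3 (0.12 log units; within the scatter). For compound 3 the estimate is 150 nM, within an expected range of 20 nM to 800 nM.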

Compound 3, half-maximal inhibitory concentration: 40 nM
Compound 3: middle estimate off by 3.8-fold (0.57 log units), on the high side; low and high end bracket the measured number.
By their numbers in this assay, from the lowest: compound 3; then compounds 2 and 1 (each within the scatter of the next).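

In this assay, the aromatic carbon ortho to a methoxy group accepts the group of 5 heavy atoms (4 oxygen, 1 phosphorus; no ring) with a 5.0-fold lower number from compound 2 to compound 3 (0.70 log units; beyond the scatter). This is the first step among the compounds shown to lie beyond the scatter, and it shows that a change at this position can lower the number, which the earlier methoxy step on the other side of the molecule could not show. No measurement at hand bears on why the number falls.

As far as these compounds go, whether a hydroxy group, an amine or a carboxylic acid on this same carbon gives a step of similar size remains open.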